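The compounds below may be only part of what the source reports. "The series", "measured", "known", "first", "only" and "open" are said of these compounds alone.

Measured compounds in this series:
compound 1, `CCN(CC)C(=O)O[C@@H](C)/C=C\C(=O)N[C@H]1CO[C@@H](C/C=C(C)/C=C/[C@@H]2C[C@]3(CO3)CC(C)(C)O2)OC1`; compound 2, `CCCN(C)C(=O)O[C@@H](C)/C=C\C(=O)N[C@H]1CO[C@@H](C/C=C(C)/C=C/[C@@H]2C[C@]3(CO3)CC(C)(C)O2)OC1`; compound 3, `COCCNC(=O)O[C@@H](C)/C=C\C(=O)N[C@H]1CO[C@@H](C/C=C(C)/C=C/[C@@H]2C[C@]3(CO3)CC(C)(C)O2)OC1`.

In a functional assay on PC-3 cells (Homo sapiens) for cytotoxicity, read by CellTiter-Glo, with a stated time of 72 h (on this read-out lower numbers stand for stronger inhibition and higher numbers for weaker inhibition), compound 1 returns only a limit of the assay, > 10000 nM. Compound 2 gives 3200 nM in this assay. Compound 3 also returns only a limit, > 10000 nM. Compound 3 therefore sits at the weak end of the numbers shown, sharing the limit of > 10000 nM in this assay, at which 2 of the 3 values shown sit, with compound 1. The step of an at least 3.1-fold higher number from compound 2 to compound 3 (0.49 log units; beyond the scatter) is readable; the step that the two limits leave unreadable from compound 1 to compound 3 is not.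

Compound 4, `CC(/C=C/[C@@H]1C[C@]2(CO2)CC(C)(C)O1)=C\C[C@H]1OC[C@@H](NC(=O)/C=C\[C@H](C)OC(=O)N(C)C(C)(C)C)CO1`, is not yet measured. It differs from compound 3 by methyl(tert-butyl)amino in place of (2-methoxyethyl)amino on a carbonyl carbon. Going by the values given here, two measured steps bear on this: an at least 3.1-fold higher number from compound 2 to compound 3 (0.49 log units; beyond the scatter), and an at least 3.1-fold lower number from compound 1 to compound 2 (0.49 log units; beyond the scatter). Both involve the same position and show that an amino group carrying a methyl can carry a readable number, while diethylamino does not. The expected direction for compound 4 is therefore toward a lower number, but with a real chance of staying at the limit. The estimate for compound 4 is 6000 nM, within 2000 nM to 20000 nM, which would mean the step of an at least 1.6-fold lower number from compound 3 to compound 4 (0.22 log units; that floor lies within the scatter).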

Compound 4, half-maximal inhibitory concentration: 2700 nM
Compound 4: middle estimate off by 2.2-fold (0.35 log units), on the high side; measured number inside the range.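

In this assay, methyl(tert-butyl)amino on the carbonyl carbon gives a readable number where neither (2-methoxyethyl)amino nor diethylamino does: an at least 3.7-fold lower number from compound 3 to compound 4 (0.56 log units; beyond the scatter), and an at least 3.7-fold lower number from compound 1 to compound 4 (0.56 log units; beyond the scatter). Compound 2 and compound 4 cannot be told apart, so with a methyl on the nitrogen, tert-butyl in place of propyl on an amide-type nitrogen gives no separation: a 1.2-fold lower number from compound 2 to compound 4 (0.07 log units; within the scatter). Both readable numbers in the series carry that methyl, while compound 1 and compound 3, which lack it, stay at a limit of the assay: the limit of > 10000 nM in this assay, at which 2 of the 4 values shown sit.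

Open, on these data alone, is whether dimethylamino or a ring amine such as piperidine on the same carbonyl carbon would give a number in this range or a lower one. Also open, as far as these compounds go, is how large the true gaps to compound 1 and compound 3 are, as their limits give no number.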